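The source may hold more compounds than are shown below. What is called first, only, known or untested is meant among the compounds shown, and "the series" means these compounds.

Measured in a functional assay on A549 cells (Homo sapiens) for inhibition, read by sulforhodamine B assay, with a stated time of 48 h; a higher number here means a weaker inhibitor of growth, a lower number a stronger inhibitor of growth:

Compound 1 `COC(=O)[C@@]1(C)CCC=C2[C@@H]1CC[C@@H](C)[C@]2(C)Cc1c(C)[nH]c2ccccc12`: 15000 nM
Compound 2 `COC(=O)[C@@]1(C)CCC=C2[C@@H]1CC[C@@H](C)[C@]2(C)Cc1c(C)[nH]c2ccc(Br)cc12`: 15000 nM
Compound 3 `COC(=O)[C@@]1(C)CCC=C2[C@@H]1CC[C@@H](C)[C@]2(C)Cc1c(C)[nH]c2ccc(Cl)cc12`: 17000 nM

Compound 3 stands alongside the other two rather than apart from them: the step from compound 1 to compound 3 is a 1.1-fold higher number from compound 1 to compound 3 (0.05 log units; within the scatter), and that from compound 2 to compound 3 is a 1.1-fold higher number from compound 2 to compound 3 (0.05 log units; within the scatter), so the three numbers cannot be told apart in this assay.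

Compound 4 `COC(=O)[C@@]1(C)CCC=C2[C@@H]1CC[C@@H](C)[C@]2(C)Cc1c(C)[nH]c2ccc(F)cc12` differs from compound 3 in one place: fluoro in place of chloro on an aromatic carbon. Every measured step bears on this change, since each swaps one substituent for another at this same aromatic carbon. From compound 1 to compound 2 the result was no change at the digits printed from compound 1 to compound 2 (within the scatter); from compound 1 to compound 3 it was a 1.1-fold higher number from compound 1 to compound 3 (0.05 log units; within the scatter); from compound 2 to compound 3 it was a 1.1-fold higher number from compound 2 to compound 3 (0.05 log units; within the scatter). Hydrogen, bromo and chloro at this carbon thus all give the same reading within the scatter, and compound 4 is expected to follow them, with a step of a 1.1-fold lower number from compound 3 to compound 4 (0.03 log units; within the scatter) from compound 3. Compound 4 is therefore estimated at 16000 nM in this assay, with a range from 8000 nM to 32000 nM.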

Compound 4, concentration for 50% growth inhibition: 15000 nM
Compound 4: middle estimate off by 1.1-fold (0.03 log units), on the high side; the range from low to high includes it.
By their numbers in this assay, from the lowest: compounds 1, 2, 4 and 3 (each within the scatter of the next).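

With fluoro, the aromatic carbon that is meta to a fused ring and para to a fused ring has now carried hydrogen, fluoro, chloro and bromo, and this assay separates none of them: the change gives a 1.1-fold lower number from compound 3 to compound 4 (0.05 log units; within the scatter) and no change at the digits printed from compound 2 to compound 4 (within the scatter) and no change at the digits printed from compound 1 to compound 4 (within the scatter). Fluoro therefore joins bromo and chloro in leaving the reading within the scatter of compound 1 at 15000 nM, so the smallest halogen shown behaves here like the two larger ones. No evidence is available that bears on why the readings stay together at this carbon.

Going by these compounds, whether an amine, a carboxylic acid or a longer chain at this carbon would shift the number remains open. So does whether changes elsewhere on the shared core would do so.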